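The compounds below may be only part of what the source reports. "The series", "measured", "known", "first", "only" and "open" are said of these compounds alone.

Measured so far in a toxicity assay on NIH3T3 cells (Mus musculus) for cytotoxicity, read by resazurin assay; a higher number here means that more compound is needed for the effect, a lower number that less compound is needed:
- compound 1, `COC(=O)c1ccc(NCc2cncn2Cc2ccc(N)cc2)cc1-c1ccccc1` — > 10000 nM
- compound 2, `CC(C)OC(=O)c1ccc(NCc2cncn2Cc2ccc(-c3ccccc3)cc2)cc1-c1ccccc1` — > 10000 nM
- compound 3, `Cc1ccccc1-c1cc(NCc2cncn2Cc2ccc(-c3ccccc3)cc2)ccc1-c1nc2ccccc2s1` — > 1000 nM

In this assay compound 1 gives > 10000 nM, which is a limit of the assay and not a number. Compound 2 gives > 10000 nM, likewise a limit. Compound 3 gives > 1000 nM, again a limit. Every value shown is thus a limit: two sit at the limit of > 10000 nM in this assay, at which 2 of the 3 values shown sit, one at the limit of > 1000 nM in this assay, at which 1 of the 3 values shown sits. Compound 1 therefore stands only at a limit, and no number places it against the others.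

Compound 4, `COC(=O)c1ccc(NCc2cncn2Cc2ccccc2[N+](=O)[O-])cc1-c1ccccc1`, differs from compound 1 in one place: 2-nitrophenyl in place of 4-aminophenyl on a saturated chain carbon bound to an aromatic nitrogen. Within the data shown here, no measured pair in this set carries this change, so no measured step is at hand. The expected step is a step that the limit leaves unreadable from compound 1 to compound 4, none beyond the scatter, because compound 1 sits at the limit of > 10000 nM in this assay, at which 2 of the 3 values shown sit, and nothing measured points elsewhere. For compound 4 the estimate is 15000 nM, with a range from 5000 nM to 50000 nM, most likely reported as a limit once more.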

Compound 4, half-maximal effective concentration: 10000 nM
The estimate for compound 4 lay 1.5-fold (0.18 log units) above the measured number, and the stated range covers the measured number.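

In this assay, among these compounds, compound 4 gives 10000 nM, the only value shown that is a number and not a limit. Putting 2-nitrophenyl in place of 4-aminophenyl on a saturated chain carbon bound to an aromatic nitrogen gives a number no higher from compound 1 to compound 4 (the limit leaves the size open). The size of this step stays open because compound 1 stands at a limit: the limit of > 10000 nM in this assay, at which 2 of the 4 values shown sit.

The swap takes away an amine and brings in a nitro group, and the point of attachment on the ring changes with it, and the compounds shown do not tell these two changes apart. On these data alone, whether a plain benzyl group, or a benzyl group carrying a carboxylic acid, would give a lower number than compound 4 at this place also stays open.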